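A few compounds are considered here, and "the series" means these few. Any claim that something is new, unique, unknown or untested is made for them only; others in the source may bear on it.

Measured in a functional assay on microsomes for inhibition, with a stated time of 1 h; a higher number here means a weaker inhibitor, a lower number a stronger inhibitor:
compound 1 `COc1ccc(-c2nc(SC)n(C)c(=O)c2C#N)cc1`: 53 ug/mL
compound 2 `CCOC(=O)c1cnn(-c2nc(-c3ccc(OC)cc3)c(C#N)c(=O)n2C)c1N`: 68 ug/mL

Compound 2, at 68 ug/mL, stands within the usual scatter of compound 1, at 53 ug/mL, so the two cannot be told apart in this assay. Both carry 4-methoxyphenyl, and they differ elsewhere on the shared core.

Compound 3 `CCOC(=O)c1cnn(-c2nc(-c3ccccc3Cl)c(C#N)c(=O)n2C)c1N` keeps the rest of compound 2 but has 2-chlorophenyl in place of 4-methoxyphenyl on an aromatic carbon. This carbon lies next to the ring nitrogen and ortho to a cyano group.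

Going by the values given here, no pair of measured compounds shows what a change at this place does, so the data offer no direct guide to its size or direction. With no evidence for a shift either way, no step beyond the scatter is expected in this assay, although the uncertainty is wide. The expected change is a 1.1-fold lower number from compound 2 to compound 3 (0.05 log units; within the scatter). For compound 3 the estimated value is 60 ug/mL, with an expected range from 22 ug/mL to 160 ug/mL.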

Compound 3, half-maximal inhibitory concentration: 102 ug/mL
The estimate for compound 3 lay 1.7-fold (0.23 log units) below the measured number, within the range that was stated.
By their numbers in this assay, from the lowest: compounds 1, 2 and 3 (each within the scatter of the next).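

In this assay, going by these compounds alone, putting 2-chlorophenyl in place of 4-methoxyphenyl on this aromatic carbon gives a 1.5-fold higher number from compound 2 to compound 3 (0.18 log units; within the scatter), the first reading of any change at this place. The two groups therefore cannot be told apart in this assay, although they differ in their heavy atoms, with chlorine in the one and oxygen in the other, and in their count of hydrogen-bond acceptors. Nothing among the available measurements bears on why the two groups read alike.

The compounds shown carry only these two substituted phenyl groups at this place, so it remains open whether an amine, a carboxylic acid or a longer alkyl chain there would give a step beyond the scatter, and whether unsubstituted phenyl would read like either group. Within the data shown here, it is also open whether 2-chlorophenyl would read the same alongside the other group, the one that sets compound 1 apart from compound 2, since only one pair of compounds speaks to this place.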